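Swapping the Chlorophenyl Arm for a Phenoxymethyl Group

The source may hold more compounds than are shown below. What is called first, only, known or untested is meant among the compounds shown, and "the series" means these compounds.

Three compounds have been measured in a functional assay on the whole organism (strain Wistar) for inhibition, with Rattus norvegicus as the target, with stated times of 30 min and 2 h, at a dose of 20 mg/kg by the oral route; on this read-out lower numbers stand for less inhibition and higher numbers for more inhibition at the one dose given (going by the name of the read-out):
- compound 1, `O=C(CCc1nnc(-c2ccc(Cl)cc2)o1)c1ccccc1`, gives 42%
- compound 2, `Cc1ccc(C(=O)CCc2nnc(-c3ccc(Cl)cc3)o2)cc1`, gives 62.7%
- compound 3, `Cc1ccc(C(=O)CCc2nnc(-c3ccc(Cl)cc3)o2)c(C)c1`, gives 53.3%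

Compound 3 stands second of the three. Its nearest neighbour is compound 2, with a number 9.4 percentage points lower from compound 2 to compound 3 (within the scatter), a step within the scatter; compound 1 is furthest, with a number 11.3 percentage points higher from compound 1 to compound 3 (beyond the scatter). The remaining step, a number 20.7 percentage points higher from compound 1 to compound 2 (beyond the scatter), likewise concerns a methyl group on the aromatic ring attached to the carbonyl carbon.

Compound 4, `Cc1ccc(C(=O)CCc2nnc(COc3ccccc3)o2)c(C)c1`, differs from compound 3 at a different place: phenoxymethyl in place of 4-chlorophenyl on an aromatic carbon. Within the data shown here, no measured step touches this position; all three involve only methyl groups on the ring at the carbonyl carbon, while the group on the five-membered aromatic ring with 2 nitrogen and 1 oxygen is the same in every measured compound. There is thus nothing to lean on, and no step beyond the scatter is expected in this assay in either direction, though the uncertainty is wide. Compound 4 is therefore estimated at 50%, with a range from 28% to 70%, which amounts to an expected step of a number 3.3 percentage points lower from compound 3 to compound 4 (within the scatter).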

Compound 4, a percentage reported as inhibition, in the whole organism at one dose (the size of the read-out at that dose, not a potency): 27.6%
Beside the measured number, compound 4's estimate is 22.4 percentage points above it; measured number outside the range, below it.
By their numbers in this assay, from the lowest: compound 4; then compound 1; then compounds 3 and 2 (each within the scatter of the next).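

The position on the five-membered ring, unchanged until now, turns out to matter in this assay: phenoxymethyl in place of 4-chlorophenyl gives a number 25.7 percentage points lower from compound 3 to compound 4 (beyond the scatter), so the read-out responds to more than the methyl groups on the ring at the carbonyl. This single change does several things at once: the chlorine goes, an oxygen enters, the heavy atom count goes from 7 to 8, and the hydrogen-bond acceptors go from 0 to 1. No measurement shown here explains the drop or separates these differences.

On these data alone, whether a plain phenyl or a 4-fluorophenyl at this place would keep the higher number remains open. So does whether phenoxymethyl would give a similar step on the core of compound 2.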